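The source may report more compounds than this note shows. Statements on the series, on what has been measured and on what is new or still open speak of the compounds shown alone.

Compound 1 `CCCCC/C=C/C=C/C=N/Nc1nc(N)c2ncn([C@@H]3O[C@H](CO)[C@@H](O)[C@H]3O)c2n1`: 2 nM
Compound 2 `Nc1nc(N/N=C/c2ccc(C(F)(F)F)cc2C(F)(F)F)nc2c1ncn2[C@@H]1O[C@H](CO)[C@@H](O)[C@H]1O`: > 10000 nM
Compound 3 `Nc1nc(N/N=C/c2ccc(N3CCCC3)cc2)nc2c1ncn2[C@@H]1O[C@H](CO)[C@@H](O)[C@H]1O`: 5.1 nM

The three measured compounds share one core and differ only in the group hanging from the carbon that carries a double bond to nitrogen. In an assay on CHO-K1 cells for displacement of a labelled ligand from adenosine receptor A1 (Homo sapiens), read by scintillation counting, with a stated time of 60 min (on this read-out lower numbers stand for stronger inhibition and higher numbers for weaker inhibition), compound 1 gives 2 nM and compound 3 gives 5.1 nM. In this assay compound 2 yields no number, only a limit, > 10000 nM. Among the two numbers compound 3 stands highest: the step of a 2.6-fold higher number from compound 1 to compound 3 (0.41 log units; beyond the scatter) is modest but beyond the scatter.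

The unmeasured compound 4 `Nc1nc(N/N=C/c2ccc(C(F)(F)F)cc2)nc2c1ncn2[C@@H]1O[C@H](CO)[C@@H](O)[C@H]1O` is compound 3 with a single change: trifluoromethyl in place of pyrrolidin-1-yl on an aromatic carbon. Within the data shown here, no measured step covers this exchange directly. Among the measured compounds shown here, the only hint comes from compound 2, which carries two trifluoromethyl groups and sits at the limit of > 10000 nM in this assay, at which 1 of the 3 values shown sits. On these data alone, compound 4 carries one, so its number is expected to move upward from compound 3, although how far remains open. The step from compound 3 is estimated as a 59-fold higher number from compound 3 to compound 4 (1.77 log units; beyond the scatter). Compound 4 is therefore expected to give about 300 nM in this assay, with a plausible range from 30 nM to 5000 nM.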

Compound 4, inhibition constant: 37 nM
The estimate for compound 4 lay 8.1-fold (0.91 log units) above the measured number, within the range that was stated.
By their numbers in this assay, from the lowest: compound 1; then compound 3; then compound 4. At a limit, above all of these: compound 2.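

In this assay, trifluoromethyl in place of pyrrolidin-1-yl on this aromatic carbon gives a 7.3-fold higher number from compound 3 to compound 4 (0.86 log units; beyond the scatter), so this exchange is tolerated with only a modest loss, while the comparison with the open chain gives a 19-fold higher number from compound 1 to compound 4 (1.27 log units; beyond the scatter), a large gap. Hydrogen in place of the second trifluoromethyl group gives an at least 270-fold lower number from compound 2 to compound 4 (2.43 log units; beyond the scatter), which shows that a single trifluoromethyl group keeps a measurable number and that most of the loss seen in compound 2 goes with the second group, not with trifluoromethyl as such. Compound 2 still gives only a limit, so the true size of that step stays unknown: the limit of > 10000 nM in this assay, at which 1 of the 4 values shown sits.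

Among these compounds, only two groups are compared on this aromatic carbon, so it stays open whether a dimethylamino group, a methoxy group or a carboxylic acid there would give a number nearer that of compound 3 or that of compound 4. On these data alone, it also stays open why the second trifluoromethyl group costs so much, and whether a chlorine atom or a methyl group in its place would cost as much.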